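Second chloro on the acetoxymethyl enone of compound 2

The compounds below may be only part of what the source reports. "The series", "measured", "known", "first", "only" and "open" are said of these compounds alone.

Compound 2, `CC(=O)OC/C(=C\c1ccc(Cl)cc1)C(=O)c1ccccc1`: 2300 nM
Compound 1, `O=C(/C(=C/c1ccc(Cl)cc1Cl)CCl)c1ccccc1`: 3100 nM

Of the compounds shown here, two have been measured in a functional assay on HBL-100 cells (Homo sapiens) for inhibition, read by sulforhodamine B assay, with a stated time of 48 h; a higher number here means a weaker inhibitor of growth, a lower number a stronger inhibitor of growth. Compound 2 `CC(=O)OC/C(=C\c1ccc(Cl)cc1)C(=O)c1ccccc1` gives 2300 nM in this assay. Compound 1 `O=C(/C(=C/c1ccc(Cl)cc1Cl)CCl)c1ccccc1` gives 3100 nM in this assay. Compound 2 stands at one end of these two numbers, but the gap to compound 1 falls within the usual scatter of repeated measurements, so the two compounds cannot be told apart on growth inhibition.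

Compound 3 `CC(=O)OC/C(=C\c1ccc(Cl)cc1Cl)C(=O)c1ccccc1` differs from compound 2 by chloro in place of hydrogen on an aromatic carbon. Within the data shown here, no pair of measured compounds differs in only this one place, so the step is not known directly. Compound 1 carries the same two chloro groups as compound 3 but a chloromethyl rather than an acetoxymethyl, and its number sits within the scatter of compound 2. On that basis the step in this assay is expected to be none beyond the scatter, in either direction. Compound 3 is therefore estimated at 2500 nM, with a range from 1000 nM to 6500 nM. The expected step is a 1.1-fold higher number from compound 2 to compound 3 (0.04 log units; within the scatter).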

Compound 3, concentration for 50% growth inhibition: 3100 nM
Estimate against measurement, compound 3: 1.2-fold (0.09 log units) below, within the range that was stated.
By their numbers in this assay, from the lowest: compounds 2, 1 and 3 (each within the scatter of the next).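

Among these compounds, the step of a 1.3-fold higher number from compound 2 to compound 3 (0.13 log units; within the scatter) gives the first direct reading in this assay of chloro in place of hydrogen on an aromatic carbon, here ortho to a large group and meta to a chloro group. On the acetoxymethyl enone, this position therefore takes the chloro without a difference that the assay can resolve. Compound 1 and compound 2 differ in more than one place and could not separate the side chain from the ring, but the step of no change at the digits printed from compound 1 to compound 3 (within the scatter) now isolates acetoxy in place of chloro on a saturated chain carbon bound to a double-bonded chain carbon, with both ring chloro groups shared, and this change also stays within the scatter.

Going by these compounds, whether a methoxy group or a carboxylic acid on that aromatic carbon, or an amine or a longer chain on the saturated chain carbon, would give a step beyond the scatter remains open. No measurement shown here bears on the reason for either step.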